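A few compounds are considered here, and "the series" means these few. Any claim that something is new, unique, unknown or untested is made for them only; others in the source may bear on it.

Compound 1 `Clc1cccc(Sc2ccnc(-c3ccccn3)n2)c1`: 620 nM
Compound 2 `CC(=O)N(c1ccc(Cl)cc1)c1ccnc(-c2ccccn2)n1`: > 10000 nM

In a functional assay for inhibition of metabotropic glutamate receptor 5 (Homo sapiens), read by FLIPR and calcium flux (on this read-out higher numbers stand for weaker inhibition and lower numbers for stronger inhibition), compound 1 gives 620 nM. For compound 2 the assay reports no number but only a limit, > 10000 nM. Of the two values shown, one sits at the limit of > 10000 nM in this assay, at which 1 of the 2 values shown sits, and that one belongs to compound 2, so where compound 2 truly stands within the weak range is not known. Compound 3 `Clc1ccc(Nc2ccnc(-c3ccccn3)n2)cc1` differs from compound 2 by hydrogen in place of acetyl on a nitrogen on an aromatic ring. For the measured compounds named here, no measured pair shows this same change, so no measured step fixes its size. Compound 3 is nonetheless expected to inhibit more strongly than compound 2, with an expected step of an at least 6.6-fold lower number from compound 2 to compound 3 (0.82 log units; beyond the scatter) that goes beyond the usual scatter. In this assay compound 3 is estimated at 1500 nM, with a range from 250 nM to 9000 nM.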

Compound 3, half-maximal inhibitory concentration: > 10000 nM
Compound 3 ended at the assay's limit; the forecaster's own chance of this, stated with the estimate: 25%; at least 6.6-fold (0.82 log units) between middle value and limit.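

No step can be read from compound 2 to compound 3, because both compounds give only a limit and not a number: the limit of > 10000 nM in this assay, at which 2 of the 3 values shown sit.

The compounds shown leave open how weakly either truly inhibits, and whether hydrogen in place of acetyl on a nitrogen on an aromatic ring changes inhibition at all.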